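This account rests on a few compounds, and the source may have more. Where it says the series, first, only, none or still open, it means among the compounds named here.

Notes on the series. Compound 3 `CC(C)CNc1nc(N)nc2c1ncn2/C=C1/CC1(CO)CO` carries an isobutylamino group on the shared core. In an ADME assay on CCRF-HSB-2 cells (Homo sapiens) for cytotoxicity, with a stated time of 7 days (a higher number here means that more compound is tolerated, a lower number that less compound is tolerated), compound 3 gives > 20000 nM, which is a limit of the assay and not a number. Compound 1 `Nc1nc(NC2CCCCC2)c2ncn(/C=C3/CC3(CO)CO)c2n1` gives > 20000 nM in this assay, again a limit. Compound 2 `Nc1nc(NC2CC2)c2ncn(/C=C3/CC3(CO)CO)c2n1` gives > 20000 nM, also a limit. With all three at the limit of > 20000 nM in this assay, at which 3 of the 3 values shown sit, the steps among them cannot be read: a step that the two limits leave unreadable from compound 1 to compound 2, a step that the two limits leave unreadable from compound 1 to compound 3 and a step that the two limits leave unreadable from compound 2 to compound 3 stay unreadable in size and direction. Compound 3 thus stands where every measured compound stands, at the limit, with no number to mark it out.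

Compound 4 `CCCSc1nc(N)nc2c1ncn2/C=C1/CC1(CO)CO` is not yet measured. It differs from compound 3 by propylsulfanyl in place of isobutylamino on an aromatic carbon. Within the data shown here, the measured steps that bear on it are all unreadable, so no size of step in this assay can be taken from them; they show only that exchanges of the group on the nitrogen left every value at the limit, and the present change, to a sulfur-bearing group, is covered by none of them. For compound 4 the expected value in this assay is 30000 nM, with an estimated range of 12000 nM to 80000 nM. The step that the limit leaves unreadable from compound 3 to compound 4 that this estimate means is expected to be none beyond the scatter, with compound 4 most likely again reported only as a limit.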

Compound 4, half-maximal cytotoxic concentration: 98000 nM
Estimate against measurement, compound 4: 3.3-fold (0.51 log units) below; the measured number lies above the stated range.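

Among these compounds, no step to compound 4 from compound 1, compound 2 or compound 3 can be read, because those three compounds are reported only as limits: the limit of > 20000 nM in this assay, at which 3 of the 4 values shown sit. The compounds shown leave open the size and direction of the exchange for propylsulfanyl in this assay.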